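This account rests on a few compounds, and the source may have more. Where it says the series, first, only, none or still open, it means among the compounds named here.

Compound 1 `CCC(c1ccccc1)c1cc(O)nc(SC(C)C)n1` and compound 2 `CCC(C)Sc1nc(O)cc(C(CC)c2ccccc2)n1` are built on one shared core, while compound 3 `CC(c1cc(O)nc(SC2CCCC2)n1)c1c(Cl)cccc1Cl` and compound 4 `CCC(c1cc(O)nc(SC2CCCC2)n1)c1c(Cl)cccc1Cl` are built on another; how the two cores differ is not broken down here. The three measured compounds were tested in a functional assay on MT4 cells (Homo sapiens) for cytotoxicity; on this read-out higher numbers stand for lower toxicity in this test and lower numbers for higher toxicity in this test. Compound 1 gives only a limit of the test, > 200000 nM, and not a number. Compound 2 likewise gives only a limit, > 200000 nM. The change between these two, (methyl in place of hydrogen on a saturated chain carbon, two bonds along the chain from a sulfur), therefore made a step that the two limits leave unreadable from compound 1 to compound 2, because both values sit at the limit of > 200000 nM in this assay, at which 2 of the 3 values shown sit. For the measured compounds named here, compound 3 gives a number in this assay, 78300 nM, the only number among the three.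

Compound 4 differs from compound 3 by methyl in place of hydrogen on a saturated chain carbon, two bonds along the chain from two aromatic carbons. Going by the values given here, this is the same kind of change as the one from compound 1 to compound 2, but not the same: there the carbon that gains the methyl sits two bonds along the chain from a sulfur, here two bonds along the chain from two aromatic carbons. The earlier step could not be sized, so it offers no measured yardstick. Beside that unreadable step, the step expected here is a 1.1-fold lower number from compound 3 to compound 4 (0.05 log units; within the scatter), resting on compound 3 giving 78300 nM and on the entering group being a single methyl. Compound 4 is thus expected to give about 70000 nM, estimated to lie between 25000 nM and 200000 nM.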

Compound 4, half-maximal cytotoxic concentration: 70000 nM
Compound 4: the middle estimate sits on the measured number at the digits printed; measured number inside the range.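

On the core of compound 3, methyl in place of hydrogen on a saturated chain carbon, two bonds along the chain from two aromatic carbons, gives a 1.1-fold lower number from compound 3 to compound 4 (0.05 log units; within the scatter) in this assay, so at this place on this core the added methyl leaves no change that the test can separate from ordinary repeat scatter. The change of the same kind on the core of compound 1 sits at a different place, two bonds along the chain from a sulfur, and its size cannot be read because compound 1 and compound 2 both give only a limit: the limit of > 200000 nM in this assay, at which 2 of the 4 values shown sit. The series therefore offers just one sized step, on one core, and this shows nothing about whether the result carries over to the other core, where a real shift could stay hidden at the limit.

The compounds shown leave open what a group other than methyl would do at these chain carbons on either core, for example a longer chain such as propyl, an amine or a carboxylic acid. Going by these compounds, whether any such group would bring the core of compound 1 away from its limit and give a number that can be compared also stays open.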